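Varying the group on the carbonyl carbon

This account rests on a few compounds, and the source may have more. Where it says the series, first, only, none or still open, it means among the compounds named here.

Compound 1 `Cc1nc(S(C)(=O)=O)ccc1Oc1ncnc(OC2CCN(C(=O)OC(C)F)CC2)c1F` gives 315 nM in a functional assay on isolated protein for inhibition of Glucose-dependent insulinotropic receptor (Rattus norvegicus), read by HTRF and cAMP accumulation (on this read-out lower numbers stand for an effect already at smaller amounts and higher numbers for an effect only at larger amounts of compound), the highest of the three numbers in hand. Compound 2 `Cc1nc(S(C)(=O)=O)ccc1Oc1ncnc(OC2CCN(C(=O)O[C@H](C)C(F)(F)F)CC2)c1F` gives 110 nM, and compound 3 `Cc1nc(S(C)(=O)=O)ccc1Oc1ncnc(OC2CCN(C(=O)SC3CC3)CC2)c1F` gives 126 nM. The change to compound 4 `CCC(F)(F)C(=O)N1CCC(Oc2ncnc(Oc3ccc(S(C)(=O)=O)nc3C)c2F)CC1` is a group of 5 heavy atoms (3 carbon, 2 fluorine; no ring) in place of a group of 4 heavy atoms (2 carbon, 1 oxygen, 1 fluorine; no ring), on a carbonyl carbon. Going by the values given here, two measured steps bear on it, both altering the same carbonyl carbon: a 2.9-fold lower number from compound 1 to compound 2 (0.46 log units; beyond the scatter) and a 2.5-fold lower number from compound 1 to compound 3 (0.40 log units; beyond the scatter). Each lowers the number modestly and beyond the scatter, while the two products sit within the scatter of each other, a 1.1-fold higher number from compound 2 to compound 3 (0.06 log units; within the scatter). For compound 4 a step of similar size and direction is expected, a 2.1-fold lower number from compound 1 to compound 4 (0.32 log units; beyond the scatter), though the entering group has no ring and the range is kept wide. Compound 4 is estimated at 150 nM, between 60 nM and 400 nM.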

Compound 4, half-maximal effective concentration: 69.2 nM
Compound 4: the middle estimate sits 2.2-fold (0.34 log units) above what was measured; the range from low to high includes it.
By their numbers in this assay, from the lowest: compounds 4, 2 and 3 (each within the scatter of the next); then compound 1.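

Putting 1,1-difluoropropyl on the carbonyl carbon, a group with no oxygen, still lowers the number in this assay (a 4.6-fold lower number from compound 1 to compound 4 (0.66 log units; beyond the scatter)). The result does not separate this group from the other two (a 1.8-fold lower number from compound 3 to compound 4 (0.26 log units; within the scatter); a 1.6-fold lower number from compound 2 to compound 4 (0.20 log units; within the scatter)), so three differently built groups on this carbonyl carbon now stand level. No measurement at hand accounts for this.

Open: whether a plain propyl chain, without fluorine, would stay level with compound 4, and whether an amine on this carbonyl carbon would do the same.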